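A few compounds are considered here, and "the series" means these few. Any claim that something is new, unique, unknown or untested is made for them only; others in the source may bear on it.

Going by the values given here, in a functional assay (muscle tissue) with Cavia porcellus as the target (a higher number here means that more compound is needed for the effect, a lower number that less compound is needed), compound 2 (`COC(=O)C1=C(C)N=C(C)/C(=C(\O)OC)C1c1cccc(C#N)c1`) gives 34.7 nM, the lower of the two numbers so far, while compound 1 (`COC(=O)C1=C(C)N=C(C)/C(=C(\O)OC)C1c1cccc(OC(C)=O)c1`) gives 6030 nM. Compound 3 (`COC(=O)C1=C(C)N=C(C)/C(=C(\O)OC)C1c1cccc([N+](C)(C)C)c1`) replaces the cyano group on the aromatic carbon with a larger group carrying a net charge of +1: a group of 4 heavy atoms (3 carbon, 1 nitrogen; no ring) in place of a group of 2 heavy atoms (1 carbon, 1 nitrogen; no ring), on an aromatic carbon. Among the compounds with values here, the only measured step at this place, a 170-fold lower number from compound 1 to compound 2 (2.24 log units; beyond the scatter), was large, so the group here can shift the number a long way. Within the data shown here, no measured compound carries a charged group, so this is a rough guide. A large rise is expected in this assay, and the estimated change is a 120-fold higher number from compound 2 to compound 3 (2.06 log units; beyond the scatter). For compound 3 the expected value is 4000 nM, within an estimated range of 400 nM to 40000 nM.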

Compound 3, half-maximal effective concentration: 50100 nM
Estimate against measurement, compound 3: 13-fold (1.10 log units) below, and the stated range ends below it.
By their numbers in this assay, from the lowest: compound 2; then compound 1; then compound 3.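

In this assay, this position on the aromatic ring moves the number upward as well as downward: putting in the group with net charge +1 gives a very large rise (a 1400-fold higher number from compound 2 to compound 3 (3.16 log units; beyond the scatter)). Heavy-atom count alone does not set the number, as the acetoxy group and the new group both have 4 heavy atoms, yet the number still rises (an 8.3-fold higher number from compound 1 to compound 3 (0.92 log units; beyond the scatter)). Nothing available here bears on the cause of these steps. The compounds shown leave open whether the net charge itself matters; a tert-butyl group at this place, with no charge, would speak to that.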